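The compounds below may be only part of what the source reports. "The series", "measured", "known", "first", "only" and "open" are said of these compounds alone.

Compound 1 `CC(C)CCn1c(Cn2c(=O)n(C(C)C)c3ccccc32)nc2cc(CN(C)C)ccc21` is one of three compounds assessed in an ADME assay on HEp-2 cells (Homo sapiens) for cytotoxicity; a higher number here means that more compound is tolerated, a lower number that less compound is tolerated. There compound 1 gives 5650 nM, the second highest of the three numbers. Compound 3 `CC(=O)c1ccc2c(c1)nc(Cn1c(=O)n(C)c3ccccc31)n2CCC(C)C` gives 5200 nM, a result within the scatter of compound 1, while compound 2 `CC(C)CCn1c(Cn2c(=O)n(C(C)C)c3ccccc32)nc2ccc(C(=O)O)cc21` gives 125000 nM, far above both. Compound 4 `COC(=O)c1ccc2c(c1)nc(Cn1c(=O)n(C(C)C)c3ccccc31)n2CCC(C)C` has not yet been measured; it differs from compound 1 by one change: methoxycarbonyl in place of (dimethylamino)methyl on an aromatic carbon. Because compound 2 gives 125000 nM and compound 3 gives 5200 nM, the step of a 2.1-fold higher number from compound 1 to compound 4 (0.33 log units; beyond the scatter) is expected to be upward and modest, perhaps just beyond the scatter. Compound 4 is therefore estimated at 12000 nM, within a range from 4000 nM to 40000 nM.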

Compound 4, half-maximal cytotoxic concentration: 33700 nM
Compound 4: the middle estimate sits 2.8-fold (0.45 log units) below what was measured, and the stated range covers the measured number.
By their numbers in this assay, from the lowest: compounds 3 and 1 (each within the scatter of the next); then compound 4; then compound 2.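

In this assay the change to methoxycarbonyl in place of (dimethylamino)methyl on this aromatic carbon brings a 6.0-fold higher number from compound 1 to compound 4 (0.78 log units; beyond the scatter) with the rest of the structure unchanged. This single pair therefore shows that the group held at this position can by itself move the tolerated concentration beyond the scatter. No measurement given here explains the step. The compounds shown leave open where an amide or a nitrile on this same carbon would fall relative to compound 1 and compound 4.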